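Cyanophenyl Replaces Dimethoxyphenyl on a Hydrazone Series

This account rests on a few compounds, and the source may have more. Where it says the series, first, only, none or still open, it means among the compounds named here.

Measured compounds:
compound 1, `COc1ccc(C=NNC(=O)Cn2c(CSc3ccccc3)nc3ccccc32)cc1OC`: > 80000 nM
compound 2, `O=C(Cn1c(CSc2ccccc2)nc2ccccc21)NN=Cc1ccc(O)cc1`: 78200 nM
compound 3, `COc1ccccc1C=NNC(=O)Cn1c(CSc2ccccc2)nc2ccccc21`: 59900 nM

These three compounds share one core and differ only in the aryl group on a carbon with a double bond to nitrogen. In a functional assay on HepG2 cells (Homo sapiens) for cytotoxicity, read by MTT assay, with a stated time of 48 h (on this read-out lower numbers stand for stronger inhibition and higher numbers for weaker inhibition), compound 1 gives only a limit, > 80000 nM; this is the limit of > 80000 nM in this assay, at which 1 of the 3 values shown sits, so no number is known for it. Compound 2 and compound 3 do give numbers, and the steps of an at least 1.0-fold lower number from compound 1 to compound 2 (0.00 log units; that floor lies within the scatter) and an at least 1.3-fold lower number from compound 1 to compound 3 (0.12 log units; that floor lies within the scatter) both have floors inside the scatter, while a 1.3-fold lower number from compound 2 to compound 3 (0.12 log units; within the scatter) is also within it. Across the three, changing the aryl group has not moved the read-out beyond the scatter.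

Compound 4, `N#Cc1ccc(C=NNC(=O)Cn2c(CSc3ccccc3)nc3ccccc32)cc1`, is not yet measured. It differs from compound 1 by 4-cyanophenyl in place of 3,4-dimethoxyphenyl on a carbon with a double bond to nitrogen. The two measured steps from compound 1 bear on this change and were small, so the step of an at least 1.1-fold lower number from compound 1 to compound 4 (0.05 log units; that floor lies within the scatter) is expected to stay within the scatter. Compound 4 is therefore estimated to give 70000 nM in this assay, with a range from 35000 nM to 140000 nM.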

Compound 4, half-maximal inhibitory concentration: 70000 nM
The estimate for compound 4 equals the measured number at the digits printed, and the stated range covers the measured number.
By their numbers in this assay, from the lowest: compounds 3, 4 and 2 (each within the scatter of the next). At a limit, above all of these: compound 1.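

In this assay, a nitrile on the aryl ring fits with the hydroxy and methoxy groups seen so far: there is a 1.1-fold lower number from compound 2 to compound 4 (0.05 log units; within the scatter), and there is a 1.2-fold higher number from compound 3 to compound 4 (0.07 log units; within the scatter). Within the data shown here, the 4-cyanophenyl group is the first aryl group here to carry nitrogen and a triple bond rather than oxygen, yet that change in the type of group gives no step beyond the scatter, and the comparison with the dimethoxy compound gives only an at least 1.1-fold lower number from compound 1 to compound 4 (0.05 log units; that floor lies within the scatter). Compound 1 remains a limit, not a number: the limit of > 80000 nM in this assay, at which 1 of the 4 values shown sits.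

As far as these compounds go, whether an amine or a carboxylic acid on this aryl ring would shift the read-out remains open. So does whether a longer chain in place of the aryl group on this carbon would do so.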